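The source may report more compounds than this note shows. Statements on the series, on what has been measured and on what is new or still open speak of the compounds shown alone.

Measured compounds:
- Compound 1, `C#Cc1cccc(Nc2ncnc3ccc(NC(=S)Nc4ccc(S(N)(=O)=O)cc4)cc23)c1` — 15300 nM
- Compound 2, `NS(=O)(=O)c1ccc(NC(=S)Nc2ccc3ncnc(Nc4cccc(Cl)c4F)c3c2)cc1` — 13100 nM

Both were tested in a functional assay on A-431 cells (Homo sapiens) for antiproliferative activity, read by MTT assay, with a stated time of 72 h; a lower number here means a stronger inhibitor, a higher number a weaker inhibitor. For the measured compounds named here, compound 2 gives the lowest of the two numbers, but its only neighbour, compound 1, lies within the scatter of it: the step of a 1.2-fold lower number from compound 1 to compound 2 (0.07 log units; within the scatter) is too small to count as a real difference, so nothing separates the two on the evidence here.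

Compound 3, `CCc1ccc(Nc2ncnc3ccc(NC(=S)Nc4ccc(S(N)(=O)=O)cc4)cc23)cc1`, is not yet measured. It differs from compound 2 in one place: 4-ethylphenyl in place of 3-chloro-2-fluorophenyl on a nitrogen on an aromatic ring. Going by the values given here, the only measured step that bears on this, the step from compound 1 to compound 2, also swapped the aryl group on that nitrogen, and it did not move the number beyond the scatter. On that basis no step beyond the scatter is expected, a 1.1-fold higher number from compound 2 to compound 3 (0.06 log units; within the scatter), and compound 3 is estimated at 15000 nM, within a range of 6000 nM to 40000 nM.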

Compound 3, half-maximal inhibitory concentration: 38400 nM
For compound 3 the middle estimate is 2.6-fold (0.41 log units) below the measured one, within the range that was stated.
By their numbers in this assay, from the lowest: compounds 2 and 1 (each within the scatter of the next); then compound 3.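

In this assay, the aryl group on this nitrogen turns out to matter: the earlier swap moved nothing beyond the scatter, but 4-ethylphenyl brings a modest, real change, with a 2.9-fold higher number from compound 2 to compound 3 (0.47 log units; beyond the scatter) and a 2.5-fold higher number from compound 1 to compound 3 (0.40 log units; beyond the scatter). Among these three compounds, then, compound 3 is the weakest, while 3-chloro-2-fluorophenyl and 3-ethynylphenyl cannot be told apart. Nothing measured here offers an explanation for this shift.

The compounds shown cannot separate the effect of the ethyl group itself from the effect of where it sits on the phenyl ring, since both differ from the other two aryl groups at once. Going by these compounds, it also remains open how the number would respond if an amine or a longer chain such as butyl stood in place of that ethyl.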